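A few compounds are considered here, and "the series" means these few. Any claim that something is new, unique, unknown or untested is made for them only; others in the source may bear on it.

Working notes on the series. Among the measured compounds shown here, compound 1 `CC(C)n1ncc2c(C(=O)Nc3ccccc3F)cc(-c3cccnc3)nc21` and compound 2 `CC(C)n1ncc2c(C(=O)Nc3cccc(F)c3F)cc(-c3cccs3)nc21` share one core and differ in two places at once, so no single step between them is drawn. In an ADME assay on LLC-MK2 cells (Macaca mulatta) for cytotoxicity, read by spectrophotometry and crystal violet staining, with a stated time of 4 days (on this read-out higher numbers stand for lower toxicity in this test and lower numbers for higher toxicity in this test), compound 1 gives 50000 nM. In this assay compound 2 gives 75000 nM, and its nearest neighbour on these numbers is compound 1; the two values sit within the usual scatter of each other, so nothing is said of their order. Compound 3 `CC(C)n1ncc2c(C(=O)Nc3ccc(F)cc3F)cc(-c3cccs3)nc21` is not yet measured. Against compound 2 the change is 2,4-difluorophenyl in place of 2,3-difluorophenyl on an amide-type nitrogen. For the measured compounds named here, with no step between measured compounds to lean on, the expectation for this assay is a step of no size beyond the scatter, in either direction, so that the expected step from compound 2 to compound 3 is a 1.2-fold lower number from compound 2 to compound 3 (0.06 log units; within the scatter). For compound 3 the estimate in this assay is 65000 nM, with a range from 25000 nM to 160000 nM.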

Compound 3, half-maximal cytotoxic concentration: > 200000 nM
Compound 3 was reported as a limit; the forecaster's own chance of this, stated with the estimate: 20%; middle value at least 3.0-fold (0.48 log units) away from the limit.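

In this assay compound 3 gives > 200000 nM, which is a limit of the assay and not a number. Among the compounds shown here, the change of 2,3-difluorophenyl to 2,4-difluorophenyl on an amide-type nitrogen gives the first readable step, an at least 2.6-fold higher number from compound 2 to compound 3 (0.42 log units; beyond the scatter), showing that with the same atoms joined differently this position can move the read-out beyond the scatter, which compound 1 and compound 2, differing in two places at once, could not show. The full size of the step stays unknown: the limit of > 200000 nM in this assay, at which 1 of the 3 values shown sits.

Going by these compounds, whether a 4-fluorophenyl, a 2,4-dichlorophenyl or a 4-aminophenyl at this position would read the same way remains open. Also open, on these data alone, is whether the step holds when the pyridin-3-yl group of compound 1 stands on the shared core in this assay.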